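A few compounds are considered here, and "the series" means these few. Any claim that something is new, unique, unknown or untested is made for them only; others in the source may bear on it.

Compound 2 `COc1cc(C)nc2n/c(=N/C(=O)c3c(-c4ccc(Cl)cc4Cl)noc3C)sn12` stands highest among the three measured compounds in a functional assay on the whole organism for inhibition, with Chenopodium ficifolium as the target, with a stated time of 72 h, tested at 100 mg/L (a higher number here means more inhibition of growth at the concentration tested, a lower number less inhibition of growth), where compound 2 gives 80.4%. Among the compounds with values here, compound 3 `COc1cc(SC)nc(NC(=S)NC(=O)c2c(-c3ccc(Cl)cc3Cl)noc2C)n1` gives 60.3%, and compound 1 `Cc1cc(O)nc(NC(=S)NC(=O)c2c(-c3ccc(Cl)cc3Cl)noc2C)n1` gives 46.7%; the only measured step between two compounds, a number 13.6 percentage points higher from compound 1 to compound 3 (beyond the scatter), exchanged one whole substituent for another on the shared core. Compound 4 `COc1cc(OC)n2s/c(=N\C(=O)c3c(-c4ccc(Cl)cc4Cl)noc3C)nc2n1` differs from compound 2 by methoxy in place of methyl on an aromatic carbon. Within the data shown here, no measured step bears directly on this exchange, and the single recorded step altered a different part of the molecule, so it is at best a loose guide. The step is therefore expected to be a number 2.4 percentage points lower from compound 2 to compound 4 (within the scatter) in this assay, not beyond the scatter. Compound 4 is estimated at 78%, with a range from 64% to 90%.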

Compound 4, percent growth inhibition at one concentration: 82.7%
Compound 4: the middle estimate sits 4.7 percentage points below what was measured; measured number inside the range.
By their numbers in this assay, from the lowest: compound 1; then compound 3; then compounds 2 and 4 (each within the scatter of the next).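

Methoxy in place of methyl on this aromatic carbon, on the six-membered aromatic ring with 2 nitrogen, gives a number 2.3 percentage points higher from compound 2 to compound 4 (within the scatter) in this assay. Within the data shown here, this is the only measured step at this position, and it shows that the exchange leaves growth inhibition unchanged within the scatter, so the position accepts methoxy as well as methyl in this pair. Nothing available accounts for this result. Going by these compounds, whether an amine or a longer chain such as butoxy on this carbon would keep inhibition at this level stays open. So does how compound 2 and compound 4 would compare at other concentrations.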